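Series notes: furan replacements at the saturated ring carbon

The source may report more compounds than this note shows. Statements on the series, on what has been measured and on what is new or still open speak of the compounds shown alone.

Measured compounds:
compound 1, `COc1cc(CC2C(C#N)=C(N)N(c3ccc(S(N)(=O)=O)cc3)C3=C2C(=O)CCC3)ccc1O`, 100%
compound 2, `N#CC1=C(N)N(c2ccc(S(N)(=O)=O)cc2)C2=C(C(=O)CCC2)C1c1ccco1`, 10%

In a functional assay on Ehrlich cells (Mus musculus) for antiproliferative activity, read by trypan blue exclusion, with a stated time of 2 h, tested at 100 ug/mL (a lower number here means a weaker effect, a higher number a stronger effect of the compound at the concentration tested), compound 1 gives 100%, the highest of the two numbers; the nearest is compound 2, which gives 10%. Among the compounds with values here, the one measured step, a number 90 percentage points lower from compound 1 to compound 2 (beyond the scatter), is large and beyond the scatter.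

Compound 3, `Cc1ccoc1C1C(C#N)=C(N)N(c2ccc(S(N)(=O)=O)cc2)C2=C1C(=O)CCC2`, has not yet been measured in this assay. It differs from compound 1 in one place: 3-methylfuran-2-yl in place of 4-hydroxy-3-methoxybenzyl on a saturated ring carbon.

The measured step from compound 1 to compound 2 bears on this change, since both replace the 4-hydroxy-3-methoxybenzyl group with a furan-based group on the same saturated ring carbon. That step was large and downward. For compound 3 a downward step of similar size is therefore expected, a number 80 percentage points lower from compound 1 to compound 3 (beyond the scatter), with the added methyl on the furan treated as an open question, so the range is kept wide. The estimate for compound 3 is 20%, expected to fall between 0% and 55%.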

Compound 3, a percentage reported as activity, at one concentration (the size of the read-out at that concentration, not a potency): 45%
Beside the measured number, compound 3's estimate is 25 percentage points below it; measured number inside the range.
By their numbers in this assay, from the lowest: compound 2; then compound 3; then compound 1.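

In this assay, the furan replacement at this saturated ring carbon is not fixed at one low level: methyl in place of hydrogen on an aromatic carbon of the furan gives a number 35 percentage points higher from compound 2 to compound 3 (beyond the scatter), so the read-out at this position depends on substitution on the entering ring as well as on the exchange of the whole group. The 3-methylfuran-2-yl group still leaves a large gap to the 4-hydroxy-3-methoxybenzyl group, with a number 55 percentage points lower from compound 1 to compound 3 (beyond the scatter), so the single methyl recovers only part of the loss seen with the unsubstituted furan. Nothing measured here accounts for either step.

Going by these compounds, it remains open whether the gain is specific to methyl, since an ethyl group, a methoxy group or a chlorine on the same furan carbon would test how far it extends. The data do not separate the hydroxy and methoxy substituents of compound 1 from its benzyl link. An unsubstituted benzyl group and a furan-2-ylmethyl group at the same saturated ring carbon would help to separate them.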